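The source may report more compounds than this note shows. Statements on the series, on what has been measured and on what is new or still open speak of the compounds shown alone.

Measured so far in an assay on Sf9 cells for inhibition of protein deacetylase HDAC6 (Homo sapiens), read by fluorescence, with a stated time of 40 min, tested at 100 nM; a lower number here means less inhibition, a higher number more inhibition at the concentration tested (going by the name of the read-out):

Compound 1 `Cc1ccc(-n2nc(-c3ccccc3)nc2CNc2ccc(C(=O)NO)cc2)cc1` gives 60.7%.

Compound 2 `Cc1cccc(-n2nc(-c3ccccc3)nc2CNc2ccc(C(=O)NO)cc2)c1` gives 66%.

Among the compounds with values here, only one step links the two measured compounds: a number 5.3 percentage points higher from compound 1 to compound 2 (within the scatter). The two numbers therefore lie within the scatter of each other, and compound 2 cannot be set apart from compound 1 on what has been measured.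

Compound 3 `O=C(NO)c1ccc(NCc2nc(-c3ccccc3)nn2-c2ccc(C(F)(F)F)cc2)cc1` has not yet been measured. It differs from compound 2 in one place: 4-(trifluoromethyl)phenyl in place of 3-methylphenyl on an aromatic nitrogen. Within the data shown here, the only measured step, a number 5.3 percentage points higher from compound 1 to compound 2 (within the scatter), concerns the same aromatic nitrogen and shows that moving a methyl group on that phenyl ring left this assay unchanged beyond the scatter. Among the measured compounds shown here, no measured step shows what a trifluoromethyl group in that position does, so the expectation rests on that single step alone. The step from compound 2 to compound 3 is expected to be a number 4 percentage points lower from compound 2 to compound 3 (within the scatter), nothing beyond the scatter. Compound 3 is accordingly estimated at 62%, with a range from 45% to 78%.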

Compound 3, a percentage reported as inhibition, at one concentration (the size of the read-out at that concentration, not a potency): 38.9%
The estimate for compound 3 lay 23.1 percentage points above the measured number; measured number below the stated range.
By their numbers in this assay, from the lowest: compound 3; then compounds 1 and 2 (each within the scatter of the next).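

This position on the phenyl ring is not indifferent to what it carries: moving a methyl group had shown nothing beyond the scatter, but in this assay changing the group itself gives a number 27.1 percentage points lower from compound 2 to compound 3 (beyond the scatter). The cleaner comparison changes only trifluoromethyl for methyl on an aromatic carbon and leaves the rest of the molecule as it was, and it gives a number 21.8 percentage points lower from compound 1 to compound 3 (beyond the scatter), so the identity of this group counts for more here than the placement of the methyl group did. Nothing available explains why the number falls with this change.

On these data alone, it remains open whether the fall is particular to trifluoromethyl or would also follow from other groups on this ring, such as a methoxy group, a chlorine atom or an amine. As far as these compounds go, it is also open whether trifluoromethyl would have the same effect in the place the methyl group occupies in compound 2.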